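This account rests on a few compounds, and the source may have more. Where it says the series, first, only, none or still open, it means among the compounds named here.

Measured so far in a physicochemical assay for solubility, at pH 7.4; on this read-out lower numbers stand for lower solubility and higher numbers for higher solubility:
compound 1 `Cc1cc(NC(=O)Nc2ccc(C(C)(C)C)cc2)c2ccccc2n1` gives 6200 nM
compound 2 `Cc1cc(NC(=O)Nc2ccccc2OC(F)(F)F)c2ccccc2n1` gives 4600 nM
compound 3 `Cc1cc(NC(=O)Nc2ccccc2C(F)(F)F)c2ccccc2n1` gives 3800 nM

The three compounds share a core and differ only on the second aromatic ring. Compound 1 has the largest of the three numbers on this assay, yet its gaps to compound 2 and to compound 3 both fall within the usual scatter, so the three stand together rather than apart. Among the compounds with values here, the single step between compounds differing in one place, a 1.2-fold lower number from compound 2 to compound 3 (0.08 log units; within the scatter), was also within the scatter.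

Compound 4 `Cc1cc(NC(=O)Nc2ccc(N)cc2)c2ccccc2n1` takes the step from compound 1 described as amino in place of tert-butyl on an aromatic carbon. Within the data shown here, no measured step concerns a tert-butyl or an amino group, and the one step that exists, a 1.2-fold lower number from compound 2 to compound 3 (0.08 log units; within the scatter), sits on a different position of the ring and was flat. The data therefore give no anchor for the size or direction of the change; any expectation rests on the structural change alone and carries a wide range. Compound 4 is estimated at 12000 nM, between 4000 nM and 40000 nM, meaning an expected step of a 1.9-fold higher number from compound 1 to compound 4 (0.29 log units; within the scatter).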

Compound 4, solubility: 18500 nM
Compound 4: the middle estimate sits 1.5-fold (0.19 log units) below what was measured, and the stated range covers the measured number.
By their numbers in this assay, from the lowest: compounds 3, 2 and 1 (each within the scatter of the next); then compound 4.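

In this assay, amino in place of tert-butyl on an aromatic carbon, para to a large group, gives a 3.0-fold higher number from compound 1 to compound 4 (0.47 log units; beyond the scatter), and this is the first single-place step among these compounds that lies beyond the scatter. The only earlier step, a 1.2-fold lower number from compound 2 to compound 3 (0.08 log units; within the scatter), lay within the scatter and concerned a different position, so this position is the first shown where one replacement moves the number clearly. No measurement shown accounts for the rise.

Whether the rise belongs to the entering amino group or to the departing tert-butyl stays open, as this is the only replacement shown at this position. The compounds shown also leave open how a hydroxyl, a methyl or a carboxylic acid on the same carbon would read in this assay.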